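This account rests on a few compounds, and the source may have more. Where it says the series, first, only, none or still open, it means among the compounds named here.

Among the measured compounds shown here, the three compounds measured so far share one core and differ only in the group attached to the carbonyl of an amide on a methylated nitrogen. Compound 1 `CN(C(=O)C(C)(C)C)c1ccc2[nH]c(-c3n[nH]c4ccccc34)cc2n1` carries a tert-butyl group there; in a functional assay on A549 cells (Homo sapiens) for antiproliferative activity, read by MTT assay, with a stated time of 72 h (on this read-out lower numbers stand for stronger inhibition and higher numbers for weaker inhibition), compound 1 gives 24400 nM. Compound 2 `CN(C(=O)CCc1ccccc1)c1ccc2[nH]c(-c3n[nH]c4ccccc34)cc2n1` carries a phenethyl group, and in this assay compound 2 gives 18100 nM. Compound 3 `COc1ccc(C(=O)N(C)c2ccc3[nH]c(-c4n[nH]c5ccccc45)cc3n2)cc1` carries a 4-methoxyphenyl group, and in this assay compound 3 gives 14600 nM. Compound 3 has the lowest of the three numbers, yet none of the three stands apart from the others: a 1.3-fold lower number from compound 1 to compound 2 (0.13 log units; within the scatter), a 1.7-fold lower number from compound 1 to compound 3 (0.22 log units; within the scatter) and a 1.2-fold lower number from compound 2 to compound 3 (0.09 log units; within the scatter).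

Compound 4 `Cc1ccc(S(=O)(=O)N(C)c2ccc3[nH]c(-c4n[nH]c5ccccc45)cc3n2)cc1` is not yet measured. It differs from compound 3 in that ((4-methylphenyl)sulfonyl in place of (4-methoxyphenyl)carbonyl on a nitrogen on an aromatic ring). Going by these compounds, the three measured steps bear on this only partly: each swapped the group on the carbonyl carbon and each stayed within the scatter, but none replaced the carbonyl itself by a sulfonyl, so that exchange is untested here. With nothing pointing to a move beyond the scatter, the expected step is a 1.0-fold higher number from compound 3 to compound 4 (0.01 log units; within the scatter). Compound 4 is therefore estimated at 15000 nM in this assay, with a range from 5000 nM to 45000 nM.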

Compound 4, half-maximal inhibitory concentration: 27100 nM
Estimate against measurement, compound 4: 1.8-fold (0.26 log units) below, and the stated range covers the measured number.
By their numbers in this assay, from the lowest: compounds 3, 2, 1 and 4 (each within the scatter of the next).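

Until now only the group on the carbonyl carbon had changed, whereas compound 4 replaces the carbonyl itself with a sulfonyl, and this assay shows a 1.9-fold higher number from compound 3 to compound 4 (0.27 log units; within the scatter). The same holds against the other two amides, with a 1.5-fold higher number from compound 2 to compound 4 (0.18 log units; within the scatter) and a 1.1-fold higher number from compound 1 to compound 4 (0.05 log units; within the scatter), so all four compounds lie within the scatter of one another and this nitrogen on an aromatic ring accepts either a carbonyl or a sulfonyl link without a clear separation in the read-out. This single step also swaps the 4-methoxyphenyl ring for a 4-methylphenyl ring, so the sulfonyl cannot be separated from that second difference, and nothing available offers an explanation for the result.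

Going by these compounds, it remains open whether a sulfonyl carrying the same 4-methoxyphenyl group would give a similar number, which would isolate the link itself. On these data alone, it is also open whether any group on this nitrogen can move the number beyond the scatter, for example a simple amine with neither carbonyl nor sulfonyl, or a carboxylic acid at the end of a longer chain.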